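A few compounds are considered here, and "the series" means these few. Any claim that something is new, unique, unknown or untested is made for them only; others in the source may bear on it.

Compound 1 `Cc1nc(C(C)C)n2c(O)nnc(-c3ccccc3)c12` gives > 48000 nM in a functional assay for inhibition, with Homo sapiens as the target (a lower number here means a stronger inhibitor, a higher number a weaker inhibitor), which is a limit of the assay rather than a number. Compound 2 `CCCc1nc(C)c2c(-c3ccccc3)nnc(SC)n12` likewise returns > 48000 nM in this assay, again only a limit. Both measured values thus sit together, as the limit of > 48000 nM in this assay, at which 2 of the 2 values shown sit, records. Compound 3 `CSc1nnc(-c2ccccc2)c2c(C)nc(C(C)C)n12` differs from compound 2 by isopropyl in place of propyl on an aromatic carbon. Within the data shown here, no measured step between compounds is available for a change of this kind. Compound 3 is expected to remain at the limit as well, with an estimate of 60000 nM, ranging from 20000 nM to 200000 nM. The expected step that the limit leaves unreadable from compound 2 to compound 3 is judged to lie within the usual scatter.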

Compound 3, half-maximal inhibitory concentration: > 48000 nM
Compound 3 was reported as a limit (the forecaster's own chance of this, stated with the estimate: 90%); the middle value lies beyond the limit too.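

Compound 3, like compound 1 and compound 2, sits at a limit, so no step among these compounds can be read: the limit of > 48000 nM in this assay, at which 3 of the 3 values shown sit.

The compounds shown leave open whether any change to the shared core gives a measurable value in this assay.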